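This account rests on a few compounds, and the source may have more. Where it says the series, first, only, none or still open, it means among the compounds named here.

Measured compounds in a functional assay on PANC-1 cells (Homo sapiens) for inhibition, read by Western blot, with a stated time of 24 h, tested at 50 uM; on this read-out lower numbers stand for less inhibition and higher numbers for more inhibition at the one concentration tested (going by the name of the read-out):
- compound 1 `CNC(=O)c1ccccc1SC/C=C(\C)CC/C=C(\C)CCC=C(C)C`: 39.7%
- compound 2 `COC(=O)c1ccccc1SC/C=C(\C)CC/C=C(\C)CCC=C(C)C`: 5.3%
- compound 3 `COCOC(=O)c1ccccc1SC/C=C(\C)CC/C=C(\C)CCC=C(C)C`: 2.6%

Compound 3 stands lowest of the three numbers; the step of a number 2.7 percentage points lower from compound 2 to compound 3 (within the scatter) is within the scatter, whereas a number 37.1 percentage points lower from compound 1 to compound 3 (beyond the scatter) is large. Compound 4 `CC(C)=CCC/C(C)=C/CC/C(C)=C/CSc1ccccc1C(=O)N(C)C` carries dimethylamino in place of methoxymethoxy on a carbonyl carbon. For the measured compounds named here, two measured steps bear on this: a number 34.4 percentage points lower from compound 1 to compound 2 (beyond the scatter) and a number 37.1 percentage points lower from compound 1 to compound 3 (beyond the scatter), both large drops when methylamino on the carbonyl carbon gives way to methoxy or methoxymethoxy. Compound 4 reverses that kind of change, putting dimethylamino where methoxymethoxy sat, so a large rise in this assay is expected, a number 27.4 percentage points higher from compound 3 to compound 4 (beyond the scatter). Going by the values given here, no measured compound shows whether dimethylamino matches methylamino, so the range is kept wide. Compound 4 is expected to give 30% (range 8% to 50%).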

Compound 4, a percentage reported as inhibition, at one concentration (the size of the read-out at that concentration, not a potency): 38.6%
Estimate against measurement, compound 4: 8.6 percentage points below; measured number inside the range.
By their numbers in this assay, from the lowest: compounds 3 and 2 (each within the scatter of the next); then compounds 4 and 1 (each within the scatter of the next).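

In this assay, dimethylamino on the carbonyl carbon in place of methoxymethoxy or methoxy gives large rises, a number 36 percentage points higher from compound 3 to compound 4 (beyond the scatter) and a number 33.3 percentage points higher from compound 2 to compound 4 (beyond the scatter). Methyl in place of hydrogen on the amide-type nitrogen stays within the scatter, a number 1.1 percentage points lower from compound 1 to compound 4 (within the scatter), so in this pair the amide hydrogen is not required for the read-out. Nothing available explains the gap between the nitrogen-bearing and oxygen-bearing groups.

Going by these compounds, whether an unsubstituted amino group, diethylamino or a carboxylic acid on the carbonyl carbon would fall with the nitrogen-bearing or the oxygen-bearing groups remains open. On these data alone, a shorter chain in place of the long unsaturated one also remains open.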